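Replacing the benzamide of compound 1 with an aryl urea

The compounds below may be only part of what the source reports. "The series", "measured", "known", "first", "only" and "open" are said of these compounds alone.

compound 1 `O=C(Nc1cccc(-c2nc(-c3ccc(NC(=O)c4cccnc4)cc3Cl)no2)c1)c1ccccc1` — in a functional assay on MDA-MB-231 cells (Homo sapiens) for antiproliferative activity, read by MTT assay, with a stated time of 72 h (on this read-out higher numbers stand for weaker inhibition and lower numbers for stronger inhibition), compound 1 gives 12800 nM
compound 2 `CC(=O)Nc1ccc(S(=O)(=O)Nc2cccc(-c3nc(-c4ccc(NC(=O)c5cccnc5)cc4Cl)no3)c2)cc1Cl` — compound 2 reaches only the assay limit of > 10000 nM
compound 3 `NC(=O)Nc1ccc(S(=O)(=O)Nc2cccc(-c3nc(-c4ccc(NC(=O)c5cccnc5)cc4Cl)no3)c2)cc1` — compound 3 gives 2800 nM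

Three compounds share a core and differ at the group attached to the outer anilide nitrogen. Of the two compounds with a numerical value, compound 1 stands with the higher number; compound 3 lies a clear step lower. Within the data shown here, the one measured step, an at least 3.5-fold lower number from compound 2 to compound 3 (0.55 log units; beyond the scatter), concerns a change on a sulfonyl sulfur, and compound 2 itself sits at the limit (the limit of > 10000 nM in this assay, at which 1 of the 3 values shown sits).

Compound 4 `COc1ccc(NC(=O)Nc2cccc(-c3nc(-c4ccc(NC(=O)c5cccnc5)cc4Cl)no3)c2)cc1` is not yet measured. It differs from compound 1 by (4-methoxyphenyl)amino in place of phenyl on a carbonyl carbon. Among the measured compounds shown here, none of the measured steps concerns a change on a carbonyl carbon, so the sulfonamide step offers no direct guide; the only hint is that compound 3, which also carries a urea, has the lowest number seen. Compound 4 is therefore expected to give a number not far from compound 1, with a modest move downward possible, as a 1.8-fold lower number from compound 1 to compound 4 (0.26 log units; within the scatter). The estimate for compound 4 is 7000 nM, within a range from 1800 nM to 25000 nM.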

Compound 4, half-maximal inhibitory concentration: 3000 nM
The estimate for compound 4 lay 2.3-fold (0.37 log units) above the measured number; the range from low to high includes it.
By their numbers in this assay, from the lowest: compounds 3 and 4 (each within the scatter of the next); then compound 1.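

In this assay, the carbonyl carbon that carries phenyl in compound 1 now has a measured step of its own: (4-methoxyphenyl)amino in its place gives a 4.3-fold lower number from compound 1 to compound 4 (0.63 log units; beyond the scatter). Among these compounds, the earlier compounds offered a measured step only on a sulfonyl sulfur, so this is the first evidence that a change on the carbonyl carbon can move the number beyond the scatter, and it moves downward even though the entering group is the larger of the two by its count of heavy atoms. Nothing shown here establishes why the number falls, and no measurement bears on the cause of this step.

The step joins two changes, the new amino link and the methoxy group on the ring, and the compounds shown do not separate them; a plain phenylamino group on the same carbonyl carbon would do so. From the compounds shown here alone, it also remains open whether the number would follow the same direction with another group at the place of the methoxy group, such as a chlorine, a dimethylamino group or a carboxylic acid.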